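The source may report more compounds than this note shows. Statements on the series, on what has been measured and on what is new or still open speak of the compounds shown alone.

In a functional assay on MGC-803 cells (Homo sapiens) for inhibition, read by sulforhodamine B assay (a higher number here means a weaker inhibitor, a lower number a stronger inhibitor), compound 3 `CCOc1ccc(NC2=CC(=O)c3nc4n(c3C2=O)[C@H]2OC[C@@H](O)[C@H]2OC4)cc1` gives 1110 nM. That lies within the scatter of compound 2 `O=C1C=C(Nc2ccc(Br)cc2)C(=O)c2c1nc1n2[C@H]2OC[C@@H](O)[C@H]2OC1`, at 1010 nM, and clearly under compound 1 `O=C1C=C(NCc2ccccc2)C(=O)c2c1nc1n2[C@H]2OC[C@@H](O)[C@H]2OC1`, at 2670 nM. Compound 4 `O=C1C=C(Nc2ccccc2)C(=O)c2c1nc1n2[C@H]2OC[C@@H](O)[C@H]2OC1` has hydrogen in place of ethoxy on an aromatic carbon, para to a large group: hydrogen in place of ethoxy on an aromatic carbon. The closest evidence is a 1.1-fold higher number from compound 2 to compound 3 (0.04 log units; within the scatter), where ethoxy in place of bromo stayed within the scatter. Replacing benzyl gave modest steps: 4-bromophenyl gave a 2.6-fold lower number from compound 1 to compound 2 (0.42 log units; beyond the scatter), and 4-ethoxyphenyl gave a 2.4-fold lower number from compound 1 to compound 3 (0.38 log units; beyond the scatter). No ring without a substituent has been measured, so the expectation is uncertain. The expected step in this assay is small and not beyond the scatter, a 1.1-fold higher number from compound 3 to compound 4 (0.03 log units; within the scatter). Compound 4 is expected at 1200 nM, with an estimated range of 600 nM to 2400 nM.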

Compound 4, half-maximal inhibitory concentration: 1730 nM
Compound 4: the middle estimate sits 1.4-fold (0.16 log units) below what was measured; the range from low to high includes it.
By their numbers in this assay, from the lowest: compounds 2, 3, 4 and 1 (each within the scatter of the next, the first and the last beyond it).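

The plain phenyl gives this ring carbon a reference point: losing the ethoxy means a 1.6-fold higher number from compound 3 to compound 4 (0.19 log units; within the scatter) and losing the bromo means a 1.7-fold higher number from compound 2 to compound 4 (0.23 log units; within the scatter) and so neither group is shown to matter on its own. Phenyl in place of benzyl gives a 1.5-fold lower number from compound 1 to compound 4 (0.19 log units; within the scatter) while the 4-bromophenyl and 4-ethoxyphenyl steps from benzyl went beyond the scatter, so only the substituted rings separate clearly from compound 1. No measurement here explains these steps. Still open, as far as these compounds go, is whether an amine or a carboxylic acid on this ring carbon would move the number beyond the scatter.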